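A few compounds are considered here, and "the series" means these few. Any claim that something is new, unique, unknown or untested is made for them only; others in the source may bear on it.

Compound 1 `COc1ccc(C2=NN(C3=NC(=O)/C(=C4\C(=O)Nc5ccccc54)S3)C(c3ccc(Cl)cc3)C2)cc1` and compound 2 `COc1ccc(C2=NN(C3=NC(=O)/C(=C4\C(=O)Nc5ccc(Br)cc54)S3)C(c3ccc(Cl)cc3)C2)cc1` share one core and differ only by bromo in place of hydrogen on an aromatic carbon. In a functional assay on cells (Cancer cell lines, Homo sapiens) for cytotoxicity, read by sulforhodamine B assay, with a stated time of 48 h (on this read-out lower numbers stand for stronger inhibition of growth and higher numbers for weaker inhibition of growth), compound 1 gives 100000 nM, while compound 2 gives 130 nM, so the change produced a 770-fold lower number from compound 1 to compound 2 (2.89 log units; beyond the scatter). Compound 3 `CN(C)c1ccc(C2CC(c3ccccc3)=NN2C2=NC(=O)/C(=C3\C(=O)Nc4ccccc43)S2)cc1` has a different core; the difference between the two cores is not broken down here. In this assay compound 3 gives 2550 nM. Going by the values given here, compound 4 `CN(C)c1ccc(C2CC(c3ccccc3)=NN2C2=NC(=O)/C(=C3\C(=O)Nc4ccc(Br)cc43)S2)cc1` is made from compound 3 by bromo in place of hydrogen on an aromatic carbon, the same change as the one between compound 1 and compound 2. Among the compounds with values here, because that earlier change gave a 770-fold lower number from compound 1 to compound 2 (2.89 log units; beyond the scatter), a large drop in the number is expected again, though somewhat smaller since only one such pair is known, so the expected step is a 43-fold lower number from compound 3 to compound 4 (1.63 log units; beyond the scatter). Compound 4 is thus estimated at 60 nM in this assay.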

Compound 4, concentration for 50% growth inhibition: 200 nM
For compound 4 the middle estimate is 3.3-fold (0.52 log units) below the measured one; the range from low to high includes it.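

In this assay bromo in place of hydrogen on an aromatic carbon again lowers the number, with a 13-fold lower number from compound 3 to compound 4 (1.11 log units; beyond the scatter) on the second core, so the direction of the change carries over between these two cores. The size of the step does not carry over, as the two steps differ by more than the usual scatter: the same change on two cores in this assay, a 770-fold lower number (2.89 log units; beyond the scatter) from compound 1 to compound 2 and a 13-fold lower number (1.11 log units; beyond the scatter) from compound 3 to compound 4, 60-fold (1.78 log units) apart, beyond the scatter of two such steps. Going by these compounds alone, with only two pairs, this does not show which part of the cores sets the size of the step, or how the change would behave on a third core.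

The compounds shown leave open whether fluoro, nitro or an amine at the same place would lower the number as bromo does. They also leave open whether such a group would give steps of different size on the two cores.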